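Sulfonyl chain shortening on a shared core

A few compounds are considered here, and "the series" means these few. Any claim that something is new, unique, unknown or untested is made for them only; others in the source may bear on it.

Measured compounds:
- compound 1, `COc1ccc(S(C)(=O)=O)c(NCC2=NCCN2)c1`; in an assay on CHO cells for binding affinity to Alpha-2C adrenergic receptor (Homo sapiens), read by radioligand binding (a lower number here means a stronger inhibitor, a higher number a weaker inhibitor), compound 1 gives < 5020 nM, a limit of the assay
- compound 2, `CS(=O)(=O)c1cc(F)ccc1NCC1=NCCN1`; in this assay compound 2 gives < 5020 nM, a limit of the assay
- compound 3, `CC(C)S(=O)(=O)c1ccccc1NCC1=NCCN1`; in this assay compound 3 gives < 5020 nM, a limit of the assay

Compound 3 stands only at a limit, and the other two values are limits as well: the limit of < 5020 nM in this assay, at which 3 of the 3 values shown sit. Within the data shown here, no step between measured compounds can be stated, since none of the three compounds carries a number.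

Compound 4, `CCS(=O)(=O)c1ccccc1NCC1=NCCN1`, differs from compound 3 by hydrogen in place of methyl on a saturated chain carbon bound to a saturated chain carbon and a sulfonyl sulfur, that is, isopropylsulfonyl to ethylsulfonyl. Among the measured compounds shown here, with no measured step to lean on and all three values sitting at the same limit, no step beyond the scatter is expected in this assay in either direction; it is likely that compound 4 again reports only a limit. For compound 4 in this assay the estimate is 2000 nM, within 400 nM to 10000 nM, which as a step from compound 3 means an expected step that the limit leaves unreadable from compound 3 to compound 4.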

Compound 4, inhibition constant: 2510 nM
Compound 4: the middle estimate sits 1.3-fold (0.10 log units) below what was measured, and the stated range covers the measured number.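

No size can be read for the step from compound 3 to compound 4 in this assay, since compound 3 stands only at a limit: the limit of < 5020 nM in this assay, at which 3 of the 4 values shown sit.

Going by these compounds, whether isopropylsulfonyl to ethylsulfonyl shifts the value in either direction, and by how much, remains open.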